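The source may report more compounds than this note shows. Statements on the series, on what has been measured and on what is new or still open speak of the compounds shown alone.

Working notes on the shared core of compound 2 `Nc1scc(CN2CCN(c3ccc([N+](=O)[O-])cc3)CC2)c1C(=O)c1ccc(Cl)cc1` with the group on an amine nitrogen in a ring varied. In a functional assay on CHO cells with adenosine receptor A1 (Homo sapiens) as the target, read by cAMP accumulation and immunoassay, with a stated time of 6 min, tested at 0.01 uM (a higher number here means a weaker effect of the compound at the concentration tested, a lower number a stronger effect), compound 2 gives -12%, level with compound 3 `Nc1scc(CN2CCN(c3c(F)cccc3F)CC2)c1C(=O)c1ccc(Cl)cc1`, which gives -12%, the two together the lowest of the three numbers; compound 1 `Nc1scc(CN2CCN(c3ccc(Cl)cc3F)CC2)c1C(=O)c1ccc(Cl)cc1` gives -9.2%. Compound 4 `Nc1scc(CN2CCN(c3ccc(F)c(Cl)c3)CC2)c1C(=O)c1ccc(Cl)cc1` differs from compound 2 as follows: 3-chloro-4-fluorophenyl in place of 4-nitrophenyl on an amine nitrogen in a ring. The measured steps bearing on this change, each a swap of the group on an amine nitrogen in a ring, were a number 2.8 percentage points lower from compound 1 to compound 2 (within the scatter), a number 2.8 percentage points lower from compound 1 to compound 3 (within the scatter) and no change at the digits printed from compound 2 to compound 3 (within the scatter), all within the scatter. A further such swap is therefore expected to give no step beyond the scatter in this assay, the expected step being a number 1 percentage points higher from compound 2 to compound 4 (within the scatter). Compound 4 is estimated at -11%, between -21% and -1%.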

Compound 4, a percentage reported as activity, at one concentration (the size of the read-out at that concentration, not a potency): 4.2%
Estimate against measurement, compound 4: 15.2 percentage points below; measured number outside the range, above it.
By their numbers in this assay, from the lowest: compounds 2, 3 and 1 (each within the scatter of the next); then compound 4.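

In this assay, among the compounds shown here, a number 16.2 percentage points higher from compound 2 to compound 4 (beyond the scatter) and a number 16.2 percentage points higher from compound 3 to compound 4 (beyond the scatter) and a number 13.4 percentage points higher from compound 1 to compound 4 (beyond the scatter) are the first steps beyond the scatter at this position, all three on entry of 3-chloro-4-fluorophenyl. The group on the amine nitrogen in a ring can therefore change the number, giving a weaker effect at the concentration tested in compound 4, while compounds 1, 2 and 3 stay within the scatter of each other. No measurement at hand accounts for these steps. Still open, going by these compounds, is whether 3-chlorophenyl or 4-fluorophenyl alone would give such a step, and what a non-aromatic group such as cyclohexyl would do on this nitrogen.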